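The compounds below may be only part of what the source reports. "The series", "measured", "known", "first", "only" and "open" are said of these compounds alone.

Compound 2 `c1cncc(-c2nnc(-c3c[nH]c4ccccc34)o2)c1` carries a pyridin-3-yl group on the shared core, and in a functional assay on MIA PaCa-2 cells (Homo sapiens) for cytotoxicity, read by MTT assay (a lower number here means a stronger inhibitor, a higher number a weaker inhibitor), compound 2 gives 900 nM. Among the numbers recorded it is the lowest of two; its nearest neighbour is compound 1 `c1ccc2c(-c3nnc(-c4ccncc4)o3)c[nH]c2c1`, which in this assay gives 1600 nM. The step of a 1.8-fold lower number from compound 1 to compound 2 (0.25 log units; within the scatter) lies within the scatter, so the two compounds cannot be ordered against each other. Compound 3 `COc1ccc(-c2nnc(-c3c[nH]c4ccccc34)o2)cc1` carries a methoxy-substituted phenyl group in place of the pyridyl, and in this assay compound 3 gives only > 1000000 nM, which is a limit of the assay and not a number. the limit of > 1000000 nM in this assay, at which 1 of the 3 values shown sits, thus accounts for one of the three values shown.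

Compound 4 `Clc1ccc(-c2nnc(-c3c[nH]c4ccccc34)o2)cc1` is not yet measured. It differs from compound 2 in one place: 4-chlorophenyl in place of pyridin-3-yl on an aromatic carbon. Within the data shown here, the only measured step, from compound 1 to compound 2, exchanges one pyridyl for another and stays within the scatter; it does not bear on the exchange of a pyridyl for a phenyl ring. What bears on that exchange is the limit recorded for compound 3, which replaced the same pyridyl with a phenyl ring carrying a methoxy group. Compound 4 is expected to give a clearly higher number in this assay, with the step of a 33-fold higher number from compound 2 to compound 4 (1.52 log units; beyond the scatter) expected to run toward weaker inhibition. The estimate for compound 4 is 30000 nM, within a range from 2000 nM to 1000000 nM, and it may well be reported only as a limit.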

Compound 4, half-maximal inhibitory concentration: 6460000 nM
Compound 4: the middle estimate sits 220-fold (2.33 log units) below what was measured; measured number outside the range, above it.
By their numbers in this assay, from the lowest: compounds 2 and 1 (each within the scatter of the next); then compound 4.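

In this assay the exchange of pyridin-3-yl for 4-chlorophenyl on the aromatic carbon of the five-membered ring gives a large step (a 7200-fold higher number from compound 2 to compound 4 (3.86 log units; beyond the scatter)), and the exchange of pyridin-4-yl for the same group gives one of similar order (a 4000-fold higher number from compound 1 to compound 4 (3.61 log units; beyond the scatter)). So while the two pyridyl groups could not be told apart, a ring of carbon only at this position now has a readable size, and that size is far beyond the scatter. Compound 3 carries a limit and not a number, so the step from it to compound 4 cannot be read, and the two phenyl-bearing compounds cannot be ordered against each other: the limit of > 1000000 nM in this assay, at which 1 of the 4 values shown sits.

As far as these compounds go, what stays open is whether the step follows the loss of the ring nitrogen or the arrival of the chloro group, a question that a plain phenyl ring or a pyridin-3-yl carrying a chloro group would separate. Also open, from the compounds shown here alone, is how an amine or a carboxylic acid on the six-membered ring would behave in this position.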